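One substituent removed from two related cores

This account rests on a few compounds, and the source may have more. Where it says the series, first, only, none or still open, it means among the compounds named here.

Compound 1 `O=C(c1ccc2cccc(OCc3ccc(B(O)O)cc3)c2n1)N1CCC(Oc2no[n+]([O-])c2S(=O)(=O)c2ccccc2)CC1` gives 20500 nM in a functional assay on PANC-1 cells (Homo sapiens) for cytotoxicity, read by MTT assay, with a stated time of 48 h, in the presence of a further agent that is not named here; on this read-out higher numbers stand for weaker inhibition and lower numbers for stronger inhibition. Compound 2 `O=C(c1ccc2cccc(O)c2n1)N1CCC(Oc2no[n+]([O-])c2S(=O)(=O)c2ccccc2)CC1` gives 14800 nM in this assay. The change from compound 1 to compound 2 is a hydrogen atom in place of a group of 10 heavy atoms (7 carbon, 1 boron, 2 oxygen; one six-membered aromatic ring of carbon only), on an oxygen on an aromatic ring and it made a 1.4-fold lower number from compound 1 to compound 2 (0.14 log units; within the scatter). Compound 3 `O=C(NCCCOc1no[n+]([O-])c1S(=O)(=O)c1ccccc1)c1ccc2cccc(OCc3ccc(B(O)O)cc3)c2n1` gives 17600 nM in this assay. Its core differs from the core of compound 1, and the difference between the two cores is not broken down here; the values of compound 3, compound 1 and compound 2 all lie within the scatter of one another. Compound 4 `O=C(NCCCOc1no[n+]([O-])c1S(=O)(=O)c1ccccc1)c1ccc2cccc(O)c2n1` has not yet been measured in this assay. It differs from compound 3 by a hydrogen atom in place of a group of 10 heavy atoms (7 carbon, 1 boron, 2 oxygen; one six-membered aromatic ring of carbon only), on an oxygen on an aromatic ring, the same change that separates compound 1 from compound 2, at a place described in identical words. Set beside that earlier step, the expected step is a 1.4-fold lower number from compound 3 to compound 4 (0.13 log units; within the scatter), resting on compound 1 and compound 2 because a 1.4-fold lower number from compound 1 to compound 2 (0.14 log units; within the scatter) lay within the scatter. Compound 4 is therefore expected to give about 13000 nM in this assay. The expected range for compound 4 runs from 7000 nM to 25000 nM.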

Compound 4, half-maximal inhibitory concentration: 13900 nM
Beside the measured number, compound 4's estimate is 1.1-fold (0.03 log units) below it, within the range that was stated.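

On the core of compound 3, a hydrogen atom in place of the group of 10 heavy atoms on the oxygen gave, in this assay, a 1.3-fold lower number from compound 3 to compound 4 (0.10 log units; within the scatter), and this step matches the one seen on the core of compound 1: the same change on two cores in this assay, a 1.4-fold lower number (0.14 log units; within the scatter) from compound 1 to compound 2 and a 1.3-fold lower number (0.10 log units; within the scatter) from compound 3 to compound 4, 1.1-fold (0.04 log units) apart, within the scatter of two such steps For these two cores, then, the change carries over in the plain sense that it gives the same small result on both, and nothing in these four compounds suggests that the core alters it. Both steps lie within the scatter, however, so the match does not show that the group has any real effect in this read-out, and it says nothing about cores beyond these two.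

The compounds shown leave open whether a different group on that oxygen, such as a methyl or a chain ending in an amine or a carboxylic acid, would move the number beyond the scatter. They also leave open whether the same change would give the same result on a core carrying a longer chain.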